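This account rests on a few compounds, and the source may have more. Where it says the series, first, only, none or still open, it means among the compounds named here.

Working notes on the series in a physicochemical assay for solubility, read by chemiluminescence, in phosphate buffer, measured as kinetic solubility, at pH 7.4; on this read-out lower numbers stand for lower solubility and higher numbers for higher solubility.

Compound 1 `O=C(NCC1(c2nc(-c3ccccc3)cs2)CCOCC1)c1ccc(CN2CCCCC2)cc1` stands at the top of the values seen so far in this assay. In this assay compound 1 gives >= 396000 nM, which is a limit of the assay rather than a number. This is the point described by the limit of >= 396000 nM in this assay, at which 1 of the 2 values shown sits. Compound 2 `COc1cccc(-c2csc(C3(CNC(=O)c4ccc(Cn5nc(C)cc5C)cc4)CCOCC3)n2)c1` is the second member measured; in this assay compound 2 gives 72000 nM. For the measured compounds named here, no pair of measured compounds differing in one place has been compared, so no measured step is available.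

Compound 3 `O=C(NCC1(c2nc(-c3ccccc3)cs2)CCOCC1)c1ccc(-n2ccnc2)cc1` is not yet measured. It differs from compound 1 by 1H-imidazol-1-yl in place of (piperidin-1-yl)methyl on an aromatic carbon. With compound 1 sitting at a limit, an exact step cannot be read from the data; a fall beyond the scatter is expected from compound 1 to compound 3, roughly an at least 2.6-fold lower number from compound 1 to compound 3 (0.42 log units; beyond the scatter). For compound 3 the expected solubility in this assay is 150000 nM, with a range from 40000 nM to 396000 nM.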

Compound 3, solubility: 193000 nM
Estimate against measurement, compound 3: 1.3-fold (0.11 log units) below, within the range that was stated.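

For the compounds shown here, at the aromatic carbon para to a large group, the first step that can be read in this assay is 1H-imidazol-1-yl in place of (piperidin-1-yl)methyl, which gives an at least 2.0-fold lower number from compound 1 to compound 3 (0.31 log units; beyond the scatter). Compound 1 reads >= 396000 nM, which is a limit of the assay and not a number. The step is therefore a bound, and its full size cannot be read: the limit of >= 396000 nM in this assay, at which 1 of the 3 values shown sits.

The change swaps the ring and also removes the methylene link, so the compounds shown do not separate these two parts of the step. A (1H-imidazol-1-yl)methyl or morpholin-4-ylmethyl group at the same aromatic carbon would bear on that question, and a carboxylic acid there would show how a group of another kind reads on the shared core.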